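The compounds below may be only part of what the source reports. "The series", "measured", "known", "first", "only" and "open" are said of these compounds alone.

Compound 3, `COc1nc(C2CCCCC2)ccc1[C@@H](c1ccccc1)[C@@](O)(CCN(C)C)c1cccc2ccccc12`, is the only one of this small set with a number in a toxicity assay on HeLa cells (Homo sapiens) for cytotoxicity; a lower number here means that less compound is tolerated, a higher number that more compound is tolerated. In this assay compound 3 gives 57.7 ug/mL. Compound 1, `COc1nc(-c2cccc(Cl)c2)ccc1[C@@H](c1ccccc1)[C@@](O)(CCN(C)C)c1cccc2ccccc12`, carries "nd" (no result reported) in this assay, and compound 2, `COc1nc(-c2ccccc2F)ccc1[C@@H](c1ccccc1)[C@@](O)(CCN(C)C)c1cccc2ccccc12`, likewise carries "nd" (no result reported), so compound 3 stands alone and cannot be ranked against them. Compound 4, `COc1nc(-c2ccc(Br)cc2)ccc1[C@@H](c1ccccc1)[C@@](O)(CCN(C)C)c1cccc2ccccc12`, is not yet measured. It differs from compound 3 in one place: 4-bromophenyl in place of cyclohexyl on an aromatic carbon. Going by the values given here, no step between two measured compounds is known here, so nothing shows how such a change moves this assay. With a ring of the same size entering, the step from compound 3 to compound 4 is expected to be small, a 1.4-fold lower number from compound 3 to compound 4 (0.16 log units; within the scatter), if anything toward slightly less tolerated compound. Compound 4 is therefore estimated at 40 ug/mL, with a range from 15 ug/mL to 100 ug/mL.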

Compound 4, half-maximal cytotoxic concentration: > 64 ug/mL
Compound 4 gave a limit, no number (the forecaster's own chance of this, stated with the estimate: 10%); middle value at least 1.6-fold (0.20 log units) away from the limit.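

Placing 4-bromophenyl in place of cyclohexyl on this aromatic carbon, next to the ring nitrogen, gives an at least 1.1-fold higher number from compound 3 to compound 4 (0.04 log units; that floor lies within the scatter). This is the only step shown at this position, and it reveals no drop in this assay when an aromatic ring carrying bromine replaces the non-aromatic ring. Compound 4 ends at a limit and not at a number, so the true size of the step stays hidden: the limit of > 64 ug/mL in this assay, at which 1 of the 4 values shown sits.

As far as these compounds go, what a plain phenyl, an amine or a carboxylic acid on this carbon would do remains open. So does how compound 1 and compound 2 compare, as neither has a reported result.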